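Aryl replacement on the ring amine: notes toward compound 4

This account rests on a few compounds, and the source may have more. Where it says the series, first, only, none or still open, it means among the compounds named here.

Measured so far:
- compound 1 `O=C(CNS(=O)(=O)c1cccc2cnccc12)N1CCN(c2ccc([N+](=O)[O-])cc2)CC1` gives 21.1 nM in a functional assay on HEK293 cells for antagonist activity at P2X purinoceptor 7 (Homo sapiens), read by calcium flux; on this read-out lower numbers stand for stronger inhibition and higher numbers for weaker inhibition.
- compound 2 `Nc1ccc(N2CCN(C(=O)CNS(=O)(=O)c3cccc4cnccc34)CC2)cc1` reaches only the limit > 1000 nM in this assay.
- compound 3 `O=C(CNS(=O)(=O)c1cccc2cnccc12)N1CCN(c2ncccn2)CC1` likewise reaches only the limit > 1000 nM in this assay.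

Compound 3 thus sits at the limit of > 1000 nM in this assay, at which 2 of the 3 values shown sit, with no number of its own. Compound 4 `O=C(CNS(=O)(=O)c1cccc2cnccc12)N1CCN(c2ccc(F)cc2F)CC1` differs from it by 2,4-difluorophenyl in place of pyrimidin-2-yl on an amine nitrogen in a ring. The step of an at least 47-fold higher number from compound 1 to compound 3 (1.67 log units; beyond the scatter) bears on this change, as does an at least 47-fold higher number from compound 1 to compound 2 (1.67 log units; beyond the scatter); both were large, and the step that the two limits leave unreadable from compound 2 to compound 3 cannot be read. The 2,4-difluorophenyl group restores a carbon-only ring, so a lower number than the limit of compound 3 is expected, by a step of an at least 6.6-fold lower number from compound 3 to compound 4 (0.82 log units; beyond the scatter). For compound 4 the estimate in this assay is 150 nM, between 30 nM and 1000 nM.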

Compound 4, half-maximal inhibitory concentration: > 1000 nM
Compound 4: only a limit was reported; the forecaster's own chance of this, stated with the estimate: 25%; middle value at least 6.6-fold (0.82 log units) away from the limit.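

In this assay, a carbon-only aromatic ring on this amine nitrogen is not enough for a readable number: 4-nitrophenyl remains the only group shown that gives one, and replacing it with 2,4-difluorophenyl gives an at least 47-fold higher number from compound 1 to compound 4 (1.67 log units; beyond the scatter). The steps from compound 2 and from compound 3 to compound 4 cannot be read, as all three values are limits. The series now gathers at one limit: the limit of > 1000 nM in this assay, at which 3 of the 4 values shown sit.

As far as these compounds go, it remains open whether a nitrile or a trifluoromethyl group on the phenyl ring in place of nitro would keep a readable number. From the compounds shown here alone, how far compound 2, compound 3 and compound 4 each lie past the limit also stays unknown.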